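Replacing 4-chlorophenyl with 3-cyanophenyl in a small series

A few compounds are considered here, and "the series" means these few. Any claim that something is new, unique, unknown or untested is made for them only; others in the source may bear on it.

In an ADME assay on HUVEC cells (Homo sapiens) for inhibition, read by CCK-8 assay, with a stated time of 24 h, in the presence of a further agent that is not named here (on this read-out lower numbers stand for stronger inhibition and higher numbers for weaker inhibition), compound 2 (`O=C1Nc2ccccc2/C1=C/c1ccc(-c2cn(-c3ccc(F)cc3)nn2)cc1`) gives 14700 nM and compound 3 (`O=C1Nc2ccccc2/C1=C/c1ccc(-c2cn(-c3ccc(Cl)cc3)nn2)cc1`) gives 18200 nM as measured numbers. Within the data shown here, the step between them is small (a 1.2-fold higher number from compound 2 to compound 3 (0.09 log units; within the scatter)), so compound 3 stands level with the only other exact number. Compound 1 (`O=C1Nc2ccccc2/C1=C/c1ccc(-c2cn(-c3cccc(F)c3)nn2)cc1`) is reported only as a limit (> 20000 nM).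

Compound 4 (`N#Cc1cccc(-n2cc(-c3ccc(/C=C4\C(=O)Nc5ccccc54)cc3)nn2)c1`) carries 3-cyanophenyl in place of 4-chlorophenyl on an aromatic nitrogen. Two measured exchanges at this nitrogen bear on the change, and both are only floors within the scatter (an at least 1.3-fold lower number from compound 1 to compound 2 (0.13 log units; that floor lies within the scatter)) and (an at least 1.0-fold lower number from compound 1 to compound 3 (0.04 log units; that floor lies within the scatter)). The nearest measured group by name is the 3-fluorophenyl of compound 1, whose limit (> 20000 nM) makes a limit reading possible here too. The estimated move is a 1.0-fold lower number from compound 3 to compound 4 (0.00 log units; within the scatter) and no step beyond the scatter is expected in this assay for this exchange. For compound 4 the estimated value is 18000 nM with an expected range from 8000 nM to 35000 nM in this series.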

Compound 4, half-maximal inhibitory concentration: > 20000 nM
Compound 4: a limit, no number; the forecaster's own chance of this, stated with the estimate: 45%; middle value at least 1.1-fold (0.04 log units) away from the limit.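

In this assay compound 4 gives > 20000 nM, which is a limit and not a number, and it is the only compound shown with a nitrile on the aryl group at this nitrogen. The floors of the new steps, an at least 1.0-fold higher number from compound 3 to compound 4 (0.04 log units; that floor lies within the scatter) and an at least 1.3-fold higher number from compound 2 to compound 4 (0.13 log units; that floor lies within the scatter), both lie within the scatter, so this exchange shows no readable separation from the two halogen compounds with exact numbers. The step between compound 1 and compound 4 cannot be read, and the new result adds a second compound at the assay's limit: the limit of > 20000 nM in this assay, at which 2 of the 4 values shown sit.

As far as these compounds go, whether any exchange at this nitrogen moves the number beyond the scatter stays open. The compounds shown also leave open how a 4-cyanophenyl, or a phenyl bearing an amine or a carboxylic acid, would read here.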